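The source may report more compounds than this note shows. Statements on the series, on what has been measured and on what is new or still open speak of the compounds shown alone.

Measured so far:
- Compound 1 `N#Cc1ccc(O[C@H]2CN(S(=O)(=O)c3ccccc3C#N)C[C@@]2(O)CO)cc1F`: 32%
- Compound 2 `N#Cc1ccc(O[C@H]2CN(S(=O)(=O)c3ccc(Cl)cn3)C[C@@]2(O)CO)cc1F`: 100%
- Compound 3 `N#Cc1ccc(O[C@H]2CN(S(=O)(=O)c3ccc(Cl)cc3)C[C@@]2(O)CO)cc1F`: 83%

In an ADME assay on the whole organism (Rattus norvegicus, strain Sprague-Dawley) for pharmacokinetics, read by LC-MS (a higher number here means that a larger share of the oral dose reaches the circulation, a lower number that a smaller share of the oral dose reaches the circulation), compound 3 gives 83%, the middle of the three numbers. Compound 4 `N#Cc1ccc(O[C@H]2CN(S(=O)(=O)c3ccc(C(F)(F)F)nc3)C[C@@]2(O)CO)cc1F` keeps the shared core and differs at one place: 6-(trifluoromethyl)pyridin-3-yl in place of 4-chlorophenyl on a sulfonyl sulfur. The step closest to this change is a number 17 percentage points lower from compound 2 to compound 3 (beyond the scatter), which is modest and replaces 5-chloropyridin-2-yl with 4-chlorophenyl. It suggests that a pyridinyl group on the sulfonyl sulfur may be tolerated, but it rests on one pair, and the two pyridinyl groups are not the same. The large step of a number 51 percentage points higher from compound 1 to compound 3 (beyond the scatter) concerns 2-cyanophenyl, which plays no part in this change. For the measured compounds named here, no measured compound carries trifluoromethyl, so the data do not show what that group does here. No step beyond the scatter is therefore expected, and the estimated step is a number 2 percentage points higher from compound 3 to compound 4 (within the scatter). For compound 4 the expected value is 85%, with an estimated range from 58% to 100%.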

Compound 4, oral bioavailability: 100%
Compound 4: middle estimate off by 15 percentage points, on the low side; the measured number falls inside the stated range.
By their numbers in this assay, from the lowest: compound 1; then compound 3; then compounds 2 and 4 (each within the scatter of the next).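

In this assay, the step of a number 17 percentage points higher from compound 3 to compound 4 (beyond the scatter) shows that a second pyridinyl group on the sulfonyl sulfur, this one carrying trifluoromethyl, also stands above 4-chlorophenyl, so the earlier reading from a single pair now rests on two different pyridinyl groups. The step of no change at the digits printed from compound 2 to compound 4 (within the scatter) places these two groups level, and a number 68 percentage points higher from compound 1 to compound 4 (beyond the scatter) matches the large gain already seen for 5-chloropyridin-2-yl over 2-cyanophenyl, so among these four compounds both pyridinyl groups stand above both phenyl groups, with no exception. Nothing available explains this difference between the groups on the sulfonyl sulfur.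

Going by these compounds, whether the pyridinyl ring alone carries this result remains open, as an unsubstituted pyridinyl group would be needed to separate it from chlorine and trifluoromethyl. Also open, on these data alone, is how a pyridinyl group bearing an amine or a carboxylic acid would behave at this position.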